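The compounds below may be only part of what the source reports. "The series", "measured", "known", "first", "only" and "open" are said of these compounds alone.

Compound 1 `CC(C)=CCC1Cc2c(OCCCNS(=O)(=O)c3ccc(C(F)(F)F)cc3)cc(=O)n(CCCO)c2CC1(C)C`: 0%
Compound 2 `CC(C)=CCC1Cc2c(OCCCNS(=O)(=O)c3ccc(Br)cc3)cc(=O)n(CCCO)c2CC1(C)C`: 3.7%
Compound 3 `CC(C)=CCC1Cc2c(OCCCNS(=O)(=O)c3ccc([N+](=O)[O-])cc3)cc(=O)n(CCCO)c2CC1(C)C`: 17.3%

In a functional assay on PANC-1 cells (Homo sapiens) for inhibition, read by MTT assay, with a stated time of 24 h, tested at 10 uM (a lower number here means less inhibition, a higher number more inhibition at the concentration tested (going by the name of the read-out)), compound 1 gives 0% and stands at the low end of the three numbers. Compound 2, measured at 3.7%, lies within the scatter of it, a number 3.7 percentage points higher from compound 1 to compound 2 (within the scatter). Compound 3, measured at 17.3%, lies beyond it, a number 17.3 percentage points higher from compound 1 to compound 3 (beyond the scatter), and also beyond compound 2, a number 13.6 percentage points higher from compound 2 to compound 3 (beyond the scatter).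

Compound 4 `CC(C)=CCC/C(C)=C/CC1Cc2c(OCCCNS(=O)(=O)c3ccc(C(F)(F)F)cc3)cc(=O)n(CCCO)c2CC1(C)C` is drawn from compound 1 by a single change: 3-methylbut-2-en-1-yl in place of hydrogen on a saturated chain carbon bound to a double-bonded chain carbon. For the measured compounds named here, all three measured steps exchange the group on the aromatic carbon of the sulfonamide; none of them touches the chain on the saturated chain carbon bound to a double-bonded chain carbon, so no measured step bears directly on this change. With nothing in the data to point either way, compound 4 is expected to stay close to compound 1, with a step of a number 3 percentage points higher from compound 1 to compound 4 (within the scatter), none beyond the scatter. The estimate for compound 4 in this assay is 3%, in a range from 0% to 15%.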

Compound 4, a percentage reported as inhibition, at one concentration (the size of the read-out at that concentration, not a potency): 0%
The estimate for compound 4 lay 3 percentage points above the measured number; low and high end bracket the measured number.
By their numbers in this assay, from the lowest: compounds 1, 4 and 2 (each within the scatter of the next); then compound 3.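

In this assay, the step for 3-methylbut-2-en-1-yl in place of hydrogen on a saturated chain carbon bound to a double-bonded chain carbon reads no change at the digits printed from compound 1 to compound 4 (within the scatter). For the compounds shown here, this is the first reading at this position, where the earlier steps changed only the group on the aromatic carbon, and it shows that lengthening 3-methylbut-2-en-1-yl to 3,7-dimethylocta-2,6-dien-1-yl does not raise the number when trifluoromethyl is the aromatic group. Nothing measured here offers an explanation for this result.

From the compounds shown here alone, since compound 1 already gives 0%, the step cannot show whether the longer chain would lower the number, and its effect alongside the nitro group of compound 3, at 17.3%, remains open. Also open, going by these compounds, is whether an amine or a carboxylic acid at the end of this chain would move the number in this assay.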